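Swapping hydroxy for bromo on an indole-2-carboxamide

A few compounds are considered here, and "the series" means these few. Any claim that something is new, unique, unknown or untested is made for them only; others in the source may bear on it.

Compound 1 `COc1ccccc1N1CCN(CCCNC(=O)Cc2c[nH]c3ccccc23)CC1`: 5.25 nM
Compound 2 `COc1ccccc1N1CCN(CCCNC(=O)c2cc3cc(O)ccc3[nH]2)CC1`: 26.9 nM

In an assay on isolated protein (thoracic aorta, strain Sprague-Dawley) for antagonist activity at Alpha-1D adrenergic receptor (Rattus norvegicus), with a stated time of 20 min (a higher number here means weaker binding, a lower number tighter binding), compound 2 has the highest number of the two, and compound 1 lies a 5.1-fold higher number from compound 1 to compound 2 (0.71 log units; beyond the scatter) away. Compound 3 `COc1ccccc1N1CCN(CCCNC(=O)c2cc3ccc(Br)cc3[nH]2)CC1` differs from compound 2 in one place: 6-bromo-1H-indol-2-yl in place of 5-hydroxy-1H-indol-2-yl on a carbonyl carbon. For the measured compounds named here, the only measured step, a 5.1-fold higher number from compound 1 to compound 2 (0.71 log units; beyond the scatter), changed both the link to the carbonyl and the substituent, so no measured step isolates a hydroxy-to-bromo exchange. Compound 3 is therefore expected to stay close to compound 2, with a 1.8-fold lower number from compound 2 to compound 3 (0.25 log units; within the scatter) as the estimated step. The estimate for compound 3 is 15 nM with a range from 4 nM to 60 nM.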

Compound 3, dissociation constant: 15.1 nM
Estimate against measurement, compound 3: 1.0-fold (0.00 log units) below; low and high end bracket the measured number.
By their numbers in this assay, from the lowest: compound 1; then compounds 3 and 2 (each within the scatter of the next).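

Placing 6-bromo-1H-indol-2-yl in place of 5-hydroxy-1H-indol-2-yl on the carbonyl carbon gives a 1.8-fold lower number from compound 2 to compound 3 (0.25 log units; within the scatter), so compound 2 and compound 3 cannot be told apart, even though the counted hydrogen-bond donors and acceptors differ. Compound 1 keeps the lowest number, with a 2.9-fold higher number from compound 1 to compound 3 (0.46 log units; beyond the scatter), so neither indol-2-yl group matches (1H-indol-3-yl)methyl. No measurement shown here accounts for these numbers. This exchange alters both the substituent and its location, and 5-bromo-1H-indol-2-yl would separate the two. From the compounds shown here alone, how an amine or a carboxylic acid would behave in place of the bromo also remains open.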